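The source may report more compounds than this note shows. Statements on the series, on what has been measured and on what is new or still open speak of the compounds shown alone.

For the measured compounds named here, compound 2 `Cc1ccccc1S(=O)(=O)Nc1cccc(/C=C/C(=O)c2nc3ccccc3[nH]2)c1` is one of two compounds measured here in a functional assay on MCF7 cells (Homo sapiens) for antiproliferative activity, read by MTT assay, with a stated time of 48 h (on this read-out higher numbers stand for weaker inhibition and lower numbers for stronger inhibition), and compound 2 gives 4130 nM there. The other, compound 1 `Cc1cccc(C(=O)Nc2cccc(/C=C/C(=O)c3nc4ccccc4[nH]3)c2)c1`, gives 5590 nM in this assay, so the two stand close together: the step of a 1.4-fold lower number from compound 1 to compound 2 (0.13 log units; within the scatter) falls within the usual scatter of repeat measurements, and no real separation between them can be claimed.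

Compound 3 `Cc1ccc(S(=O)(=O)Nc2cccc(/C=C/C(=O)c3nc4ccccc4[nH]3)c2)cc1` is the next compound to be tested. Its change from compound 2 is 4-methylphenyl in place of 2-methylphenyl on a sulfonyl sulfur. Going by the values given here, only one measured step exists to draw on, a 1.4-fold lower number from compound 1 to compound 2 (0.13 log units; within the scatter), and that step swaps the whole linking group together with the methyl position at once, so it does not isolate the effect of moving a methyl group around a phenyl ring. What it does show is that a change in this part of the molecule left the number within the scatter.

On that basis the expectation for compound 3 in this assay is a step of a 1.0-fold lower number from compound 2 to compound 3 (0.00 log units; within the scatter), no larger than the scatter and in no firm direction. Compound 3 is therefore estimated at 4100 nM, with a range from 1800 nM to 9500 nM.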

Compound 3, half-maximal inhibitory concentration: 3220 nM
The estimate for compound 3 lay 1.3-fold (0.10 log units) above the measured number; the range from low to high includes it.
By their numbers in this assay, from the lowest: compounds 3, 2 and 1 (each within the scatter of the next).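

Moving the methyl group around the ring on the sulfonyl sulfur, with the rest of the molecule unchanged, isolates a single change for the first time: in this assay, 4-methylphenyl in place of 2-methylphenyl gives a small step (a 1.3-fold lower number from compound 2 to compound 3 (0.11 log units; within the scatter)), so these two placements of the methyl group cannot be told apart on this read-out. Compound 3 also cannot be separated from the amide compound 1 (a 1.7-fold lower number from compound 1 to compound 3 (0.24 log units; within the scatter)), although that step exchanges the carbonyl for a sulfonyl and moves the methyl group at the same time, so it cannot assign any share of the step to either change. Taken together, the three compounds show that these variations in this part of the molecule all stay within the scatter, and no measurement here offers an explanation for the small differences.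

As far as these compounds go, what remains open is whether any group on the sulfonyl sulfur can shift the number beyond the scatter. A plain phenyl, a methoxyphenyl or a chlorophenyl ring, or a butyl chain in place of the ring, would each test this more widely than a moved methyl group can.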